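Notes on compound 4 against compounds 1 to 3

This account rests on a few compounds, and the source may have more. Where it says the series, first, only, none or still open, it means among the compounds named here.

Going by the values given here, compound 3 `CC(C)Oc1cc(-c2cccnc2)ccc1C(N)=O` gives 880 nM in an assay on cells for inhibition of MAP kinase-interacting serine/threonine-protein kinase 1 (Homo sapiens), read by mobility shift assay, with stated times of 10 min and 60 min, in the presence of a further agent that is not named here (on this read-out lower numbers stand for stronger inhibition and higher numbers for weaker inhibition), the second highest of the three numbers measured so far; compound 1 `CNC(=O)c1cncc(-c2ccc(C(N)=O)c(OC(C)C)c2)c1` gives 1900 nM and compound 2 `CC(C)Oc1cc(-c2cncc(-c3cnn(C)c3)c2)ccc1C(N)=O` gives 400 nM. Compound 4 `CC(C)Oc1cc(-c2cncc(-c3cnn(C4COC4)c3)c2)ccc1C(N)=O` is compound 3 with 1-(oxetan-3-yl)-1H-pyrazol-4-yl in place of hydrogen on an aromatic carbon. The measured step that bears most directly on this is a 2.2-fold higher number from compound 2 to compound 3 (0.34 log units; beyond the scatter), where the group leaving was 1-methyl-1H-pyrazol-4-yl; read in reverse it indicates that a group of this kind at this place lowers the number modestly, and a 4.8-fold lower number from compound 1 to compound 2 (0.68 log units; beyond the scatter) points the same way. Nothing measured shows what the oxetan-3-yl adds. Compound 4 is therefore expected to give 400 nM, with a range of 180 nM to 900 nM. The expected step is a 2.2-fold lower number from compound 3 to compound 4 (0.34 log units; beyond the scatter).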

Compound 4, half-maximal inhibitory concentration: 200 nM
Compound 4: the middle estimate sits 2.0-fold (0.30 log units) above what was measured; the measured number falls inside the stated range.
By their numbers in this assay, from the lowest: compounds 4 and 2 (each within the scatter of the next); then compound 3; then compound 1.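

In this assay, 1-(oxetan-3-yl)-1H-pyrazol-4-yl at this place gives a 4.4-fold lower number from compound 3 to compound 4 (0.64 log units; beyond the scatter), and against methylcarbamoyl it gives a 9.5-fold lower number from compound 1 to compound 4 (0.98 log units; beyond the scatter). The earlier compounds shown here said nothing about the substituent on the aromatic nitrogen; oxetan-3-yl in place of methyl gives a 2.0-fold lower number from compound 2 to compound 4 (0.30 log units; within the scatter), so this larger group is accommodated without a change beyond the scatter. Nothing at hand explains these steps. Open, going by these compounds, is whether the aromatic nitrogen also accepts an amine such as piperidin-4-yl or a carboxylic acid on a longer chain, and whether either holds the number seen with oxetan-3-yl.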